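A Chloro-to-Trifluoromethyl Swap at the Edge of Detection

This account rests on a few compounds, and the source may have more. Where it says the series, first, only, none or still open, it means among the compounds named here.

Compound 1, `Cc1[nH]nc(N)c1-c1ccc(Cl)c(Cl)c1`, in an assay on Sf9 cells for inhibition of inhibitor of nuclear factor kappa-B kinase subunit epsilon (Homo sapiens), read by ADP-Glo, with a stated time of 60 min (a higher number here means a weaker inhibitor, a lower number a stronger inhibitor), gives only a limit of the assay, > 100000 nM.
Compound 2, `Cc1[nH]nc(N)c1-c1ccc2ccccc2c1`, in this assay likewise gives only a limit, > 100000 nM.
Compound 3, `Cc1[nH]nc(N)c1-c1cccc(Cl)c1`, in this assay gives a number, 93400 nM.

Among the measured compounds shown here, compound 3 therefore stands alone among the three as the one with a measured number; the other two values are limits, a point underlined by the limit of > 100000 nM in this assay, at which 2 of the 3 values shown sit. For the measured compounds named here, the single measured step that joins two compounds differing in one place is an at least 1.0-fold lower number from compound 1 to compound 3 (0.02 log units; that floor lies within the scatter), and it sits within the scatter, so it says little about direction.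

Compound 4, `Cc1[nH]nc(N)c1-c1cccc(C(F)(F)F)c1`, differs from compound 3 in one place: trifluoromethyl in place of chloro on an aromatic carbon. Going by the values given here, no measured step concerns a trifluoromethyl group, and the one step on this aromatic carbon region, an at least 1.0-fold lower number from compound 1 to compound 3 (0.02 log units; that floor lies within the scatter), was flat. The expectation in this assay is therefore no step beyond the scatter, with the result as likely to fall at a limit as to give a number. For compound 4 the expected value is 100000 nM, within 30000 nM to 300000 nM, which amounts to an expected step of a 1.1-fold higher number from compound 3 to compound 4 (0.03 log units; within the scatter).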

Compound 4, half-maximal inhibitory concentration: > 100000 nM
Compound 4 was reported as a limit (the forecaster's own chance of this, stated with the estimate: 55%); the middle value lies on the limit itself.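

In this assay compound 4 gives > 100000 nM, which is a limit of the assay and not a number. Trifluoromethyl in place of chloro on this aromatic carbon gives an at least 1.0-fold higher number from compound 3 to compound 4 (0.02 log units; that floor lies within the scatter), so this change brings no sign of a stronger inhibitor at this position, although the true size of the step cannot be read beyond that floor. Compound 3 remains the only compound here with a measured number, and a second group at this position, with more heavy atoms than chloro, leaves the series at the edge of detection: the limit of > 100000 nM in this assay, at which 3 of the 4 values shown sit.

The compounds shown leave open whether any other group on this aromatic carbon, such as an amine or a carboxylic acid, would give a number well clear of the limit. They also leave open whether a longer chain elsewhere on the shared core would move the values in this assay, this assay, at all, or whether the series stays at the limit whatever is placed there.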